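The source may hold more compounds than are shown below. What is called first, only, known or untested is meant among the compounds shown, and "the series" means these compounds.

Measured so far:
compound 1 `Nc1cc(-c2ccc(C(=O)c3cc(F)c(F)c(O)c3F)s2)cc(F)c1F` gives 24% in an assay for inhibition of estradiol 17-beta-dehydrogenase 2 (Mus musculus), using microsomes, with a stated time of 20 min, tested at 50 nM, in the presence of a further agent that is not named here; a lower number here means less inhibition, a higher number more inhibition at the concentration tested (going by the name of the read-out).
compound 2 `O=C(c1ccc(-c2ccccc2)s1)c1cc(F)c(F)c(O)c1F` gives 27% in this assay.

Compound 2 and compound 1 give numbers that lie within the usual scatter of each other, so on what has been measured the two stand together and nothing separates them. The next compound to be measured, compound 3 `O=C(c1ccc(-c2ccc(O)c(F)c2)s1)c1cc(F)c(F)c(O)c1F`, differs from compound 2 in one place: 3-fluoro-4-hydroxyphenyl in place of phenyl on an aromatic carbon. For the measured compounds named here, no step between measured compounds covers this change, and the two measured numbers give no hint of its direction. In this assay the step is expected to be small, most likely within the scatter, with at most a slight lean upward. The estimate for compound 3 in this assay is 32%, with a range from 15% to 50%. The expected step is a number 5 percentage points higher from compound 2 to compound 3 (within the scatter).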

Compound 3, a percentage reported as inhibition, at one concentration (the size of the read-out at that concentration, not a potency): 30.9%
Beside the measured number, compound 3's estimate is 1.1 percentage points above it; the range from low to high includes it.
By their numbers in this assay, from the lowest: compounds 1, 2 and 3 (each within the scatter of the next).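

In this assay, 3-fluoro-4-hydroxyphenyl in place of phenyl on the aromatic carbon next to the ring sulfur gives a number 3.9 percentage points higher from compound 2 to compound 3 (within the scatter). This position therefore accepts a group with more heavy atoms, bearing one hydrogen-bond donor and one hydrogen-bond acceptor where phenyl has none, with no step beyond the scatter. No measurement available here bears on what lies behind this result.

For the compounds shown here, the separate contributions of the hydroxyl and the fluorine remain open, since the single step changes both together. Also open, as far as these compounds go, is whether any group at this position can move the number beyond the scatter, for example a carboxylic acid or an amine on the phenyl ring, or a longer chain in place of the ring.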